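This account rests on a few compounds, and the source may have more. Where it says the series, first, only, none or still open, it means among the compounds named here.

Measured compounds:
Compound 1 `CC(=O)N1CC2CC(C1)N2`: in an assay on CHO cells for agonist activity at Neuronal acetylcholine receptor; alpha3/alpha6/beta2/beta3 (Homo sapiens), read by FLIPR and calcium flux (on this read-out higher numbers stand for larger maximal responses and lower numbers for smaller maximal responses), compound 1 gives 100%.
Compound 2 `CCC(=O)N1CC2CC(C1)N2`: in this assay compound 2 gives 120%.

Compound 1 stands lowest of the two numbers; its nearest neighbour is compound 2, reached by a number 20 percentage points higher from compound 1 to compound 2 (beyond the scatter), a methyl in place of hydrogen on a saturated chain carbon bound to a carbonyl carbon. Compound 3 `O=C([C@H]1C[C@@H]1F)N1CC2CC(C1)N2` has not yet been measured. It differs from compound 1 by 2-fluorocyclopropyl in place of methyl on a carbonyl carbon. Among the measured compounds shown here, the only measured step that bears on this change is a number 20 percentage points higher from compound 1 to compound 2 (beyond the scatter), where enlarging the group on the carbonyl carbon raised the response modestly. For the measured compounds named here, the change to compound 3 is larger, and no measured compound shows what a three-membered ring or a fluorine does here, so an increase of similar size in this assay, or none beyond the scatter, is expected. Compound 3 is estimated at 110%, between 80% and 140%, which is expected to mean a number 10 percentage points higher from compound 1 to compound 3 (within the scatter).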

Compound 3, largest response reached (Emax), in percent of the reference or control that the assay uses: 85%
Beside the measured number, compound 3's estimate is 25 percentage points above it; the range from low to high includes it.
By their numbers in this assay, from the lowest: compound 3; then compound 1; then compound 2.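

With 2-fluorocyclopropyl in place of methyl on the carbonyl carbon, this assay shows a number 15 percentage points lower from compound 1 to compound 3 (beyond the scatter) for this change, so a larger group at this position does not always bring a larger response. Set against ethyl, the same group gives a number 35 percentage points lower from compound 2 to compound 3 (beyond the scatter) in this comparison, the largest step seen so far at this position. Nothing available here accounts for this fall.

The 2-fluorocyclopropyl group brings a three-membered ring and a fluorine at once, so the compounds shown cannot tell which of the two goes with the lower response. A plain cyclopropyl on the carbonyl carbon would separate the ring from the fluorine, and a longer chain such as propyl would show how far the rise seen with ethyl continues.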